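Working notes: 4-chlorophenyl to 4-methylphenyl

The compounds below may be only part of what the source reports. "The series", "measured", "known", "first", "only" and "open" are said of these compounds alone.

In a functional assay on A549 cells (Homo sapiens) for antiproliferative activity, read by MTT assay, with a stated time of 72 h (on this read-out lower numbers stand for stronger inhibition and higher numbers for weaker inhibition), compound 1 `Cc1nc(C)c(/C=C/C(=O)/C=C/c2cccc(O)c2)nc1C` gives 4300 nM, compound 2 `Cc1nc(C)c(/C=C/C(=O)/C=C/c2ccccc2)nc1C` gives 12300 nM, and compound 3 `Cc1nc(C)c(/C=C/C(=O)/C=C/c2ccc(Cl)cc2)nc1C` gives 15800 nM. Compound 3 cannot be separated from the unsubstituted compound 2, as the record shows a 1.3-fold higher number from compound 2 to compound 3 (0.11 log units; within the scatter). It does stand apart from the hydroxy-bearing compound 1, with the record showing a 3.7-fold higher number from compound 1 to compound 3 (0.57 log units; beyond the scatter).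

The next member, compound 4 `Cc1ccc(/C=C/C(=O)/C=C/c2nc(C)c(C)nc2C)cc1`, differs from compound 3 by methyl in place of chloro on an aromatic carbon, para to a large group (methyl in place of chloro on an aromatic carbon). Among the measured compounds shown here, no measured compound carries this methyl, so the expectation rests on indirect evidence. For the measured compounds named here, the only step that concerns the chloro group alone is small: a 1.3-fold higher number from compound 2 to compound 3 (0.11 log units; within the scatter). The modest steps all involve loss of the hydroxy group, namely a 2.9-fold higher number from compound 1 to compound 2 (0.46 log units; beyond the scatter) and a 3.7-fold higher number from compound 1 to compound 3 (0.57 log units; beyond the scatter). Compound 3 and compound 4 both lack that group, so these larger steps offer little guidance here.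

No step beyond the scatter is therefore expected in this assay. The estimate amounts to an expected 1.1-fold lower number from compound 3 to compound 4 (0.05 log units; within the scatter). The expected value for compound 4 is 14000 nM, with an estimated range of 7000 nM to 28000 nM.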

Compound 4, half-maximal inhibitory concentration: 4300 nM
Beside the measured number, compound 4's estimate is 3.3-fold (0.51 log units) above it; the measured number lies below the stated range.
By their numbers in this assay, from the lowest: compounds 1 and 4 (each within the scatter of the next); then compounds 2 and 3 (each within the scatter of the next).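

In this assay, the aromatic carbon para to a large group now proves sensitive to what it carries: the earlier chloro step could not be separated from the scatter, whereas methyl gives a 3.7-fold lower number from compound 3 to compound 4 (0.57 log units; beyond the scatter) and a 2.9-fold lower number from compound 2 to compound 4 (0.46 log units; beyond the scatter). So chloro and methyl, each a single heavy atom with no hydrogen-bond donors or acceptors, do not read alike at this place, and the unsubstituted compound 2 sits with chloro rather than with methyl. The lower number is also no longer confined to the hydroxy-bearing member of the series, with no change at the digits printed from compound 1 to compound 4 (within the scatter), so a hydroxy group is not needed to reach that level in this assay, and nothing on hand explains the gap between methyl and chloro.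

Going by these compounds, whether an ethyl, a methoxy or an amino group on the same carbon would read like compound 4 or like compound 3 stays open. Also open, on these data alone, is how a methyl on the carbon that holds the hydroxy of compound 1 would read, and whether hydroxy and methyl on one ring would add together.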